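Switching the nitrogen substituent from branched alkyl to substituted benzyl

The compounds below may be only part of what the source reports. "The series", "measured", "known", "first", "only" and "open" are said of these compounds alone.

Compound 3 `CCCCC(CCCC)n1ccc2cc(/C(C)=C/C(=O)Nc3ccccc3OCCCC(=O)O)ccc21` gives 21 nM in an assay on Prostate gland for inhibition of steroid 5-alpha-reductase (Rattus norvegicus) (on this read-out lower numbers stand for stronger inhibition and higher numbers for weaker inhibition), which places it second highest of the three numbers recorded so far: its nearest neighbour is compound 2 `CCCCC(CC)n1ccc2cc(/C(C)=C/C(=O)Nc3ccccc3OCCCC(=O)O)ccc21` with 7.1 nM, and the furthest is compound 1 `C/C(=C\C(=O)Nc1ccccc1OCCCC(=O)O)c1ccc2c(ccn2C)c1` with 780 nM. Compound 4 `C/C(=C\C(=O)Nc1ccccc1OCCCC(=O)O)c1ccc2c(ccn2Cc2ccc(C(C)(C)C)cc2)c1` differs from compound 3 in one place: 4-(tert-butyl)benzyl in place of 1-butylpentyl on an aromatic nitrogen.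

Going by the values given here, the steps that bear on this change are those altering the same nitrogen substituent. Replacing methyl gave a 110-fold lower number from compound 1 to compound 2 (2.04 log units; beyond the scatter) and a 37-fold lower number from compound 1 to compound 3 (1.57 log units; beyond the scatter), both large gains. Between the two branched alkyls the step was a 3.0-fold higher number from compound 2 to compound 3 (0.47 log units; beyond the scatter), modest. Among the compounds with values here, no measured step exchanges a branched alkyl for an aromatic-ring-bearing group, so the direction here rests only on the observation that every substituent beyond methyl on this nitrogen has so far given a far lower number than compound 1.

Compound 4 is therefore expected to stay in the region of the two branched alkyl compounds, with an estimated 1.1-fold lower number from compound 3 to compound 4 (0.02 log units; within the scatter), and an estimated value of 20 nM ranging from 5 nM to 80 nM.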

Compound 4, half-maximal inhibitory concentration: 170 nM
Compound 4: the middle estimate sits 8.5-fold (0.93 log units) below what was measured; the whole stated range lies below it.
By their numbers in this assay, from the lowest: compound 2; then compound 3; then compound 4; then compound 1.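

On this aromatic nitrogen in this assay, a ring-bearing substituent does not match the branched alkyls: the change gives an 8.1-fold higher number from compound 3 to compound 4 (0.91 log units; beyond the scatter) and a 24-fold higher number from compound 2 to compound 4 (1.38 log units; beyond the scatter), even though 4-(tert-butyl)benzyl carries more heavy atoms than 1-butylpentyl. It still keeps part of the gain over methyl, with a 4.6-fold lower number from compound 1 to compound 4 (0.66 log units; beyond the scatter), so all three larger substituents give lower numbers than methyl, though by clearly different amounts. No measurement at hand accounts for the gap between the benzyl and the branched alkyl groups.

Going by these compounds, whether the loss belongs to the aromatic ring itself or to the tert-butyl group on it remains open. A plain benzyl would help separate the two, and a cyclohexylmethyl group would test a ring that is not aromatic.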